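Saturated Ethyl in Place of Vinyl: Expected Cytotoxicity

The source may hold more compounds than are shown below. What is called first, only, known or untested is meant among the compounds shown, and "the series" means these compounds.

Compound 1 `O=S(=O)(Nc1ccc(-c2nc3ccccc3o2)cc1)c1ccccc1Cl` was tested in an ADME assay on HEK293 cells (Homo sapiens) for cytotoxicity, read by resazurin assay, with a stated time of 48 h (on this read-out lower numbers stand for higher toxicity in this test and higher numbers for lower toxicity in this test), and gives only a limit, > 100000 nM, meaning the assay reports no number for it. For the measured compounds named here, compound 2 `C=Cc1ccc(S(=O)(=O)Nc2ccc3oc(-c4ccccc4)nc3c2)cc1` gives 53000 nM in this assay, the only actual number among the two results. The other result, for compound 1, is a limit (the limit of > 100000 nM in this assay, at which 1 of the 2 values shown sits). Compound 3 `CCc1ccc(S(=O)(=O)Nc2ccc3oc(-c4ccccc4)nc3c2)cc1` differs from compound 2 by ethyl in place of vinyl on an aromatic carbon. Going by the values given here, with no measured pair to lean on, the step from compound 2 to compound 3 is expected to stay within the usual scatter, a 1.1-fold higher number from compound 2 to compound 3 (0.05 log units; within the scatter). Compound 3 is therefore estimated at 60000 nM, with a range from 25000 nM to 150000 nM.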

Compound 3, half-maximal cytotoxic concentration: 81000 nM
Compound 3: middle estimate off by 1.4-fold (0.13 log units), on the low side; low and high end bracket the measured number.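

For the compounds shown here, this is the first measured step at this place on the ring: replacing vinyl with ethyl on 4-vinylphenyl gives a 1.5-fold higher number from compound 2 to compound 3 (0.18 log units; within the scatter) in this assay. Removing the double bond outside the aromatic rings therefore produces no change in cytotoxicity that can be told apart from the usual scatter of the test. Compound 1 gives only a limit, so it offers no number for comparison: the limit of > 100000 nM in this assay, at which 1 of the 3 values shown sits.

From the compounds shown here alone, whether an amine, a carboxylic acid or a longer chain at this place would move the number beyond the scatter remains open. Also open, going by these compounds, is whether ethyl in place of vinyl would behave the same way on a different core.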